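Fluoro for chloro in a set stuck at a limit

The compounds below may be only part of what the source reports. "The series", "measured", "known", "first", "only" and "open" are said of these compounds alone.

In an ADME assay on MT4 cells (Homo sapiens) for activation, read by MTT assay (on this read-out higher numbers stand for lower toxicity in this test and lower numbers for higher toxicity in this test), compound 3 (`CCC(c1nc(SC2CCCC2)[nH]c(=O)c1C)c1c(F)cccc1Cl`) gives > 3000 nM and this is a limit. Compound 1 (`CCCSc1nc(C(CC)c2c(F)cccc2Cl)c(C)c(=O)[nH]1`) gives > 3000 nM which is also a limit. Compound 2 (`CCCCSc1nc(C(CC)c2c(F)cccc2Cl)c(C)c(=O)[nH]1`) gives > 3000 nM again as a limit. The set therefore stands at the limit of > 3000 nM in this assay, at which 3 of the 3 values shown sit, and offers no number.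

Compound 4 (`CCC(c1nc(SC2CCCC2)[nH]c(=O)c1C)c1c(F)cccc1F`) carries fluoro in place of chloro on an aromatic carbon, turning 2-chloro-6-fluorophenyl into 2,6-difluorophenyl.

Changes on the sulfur side give a step that the two limits leave unreadable from compound 1 to compound 2 then a step that the two limits leave unreadable from compound 1 to compound 3 and a step that the two limits leave unreadable from compound 2 to compound 3 and none touches the halogen. Compound 3 offers only the limit > 3000 nM as a starting point, so no step beyond the scatter is expected in this assay and no direction. The expected outcome is a step that the limit leaves unreadable from compound 3 to compound 4 and no more. Compound 4 is estimated at 4000 nM within an expected range of 2000 nM to 20000 nM and may again report only a limit.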

Compound 4, half-maximal cytotoxic concentration: 30000 nM
Estimate against measurement, compound 4: 7.5-fold (0.88 log units) below, and the stated range ends below it.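

Among the compounds shown here, compound 3 is held only as a limit, so no step from it to compound 4 can be read. The compounds shown leave open whether fluoro in place of chloro shifts the read-out in this assay, and in which direction.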